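The compounds below may be only part of what the source reports. "The series", "measured", "known", "first", "only" and "open" are said of these compounds alone.

Measured so far in an ADME assay on Vero cells (Chlorocebus sabaeus) for cytotoxicity, read by microscopy; a lower number here means that less compound is tolerated, a higher number that more compound is tolerated:

compound 1 `CSc1nc(OCCCNc2ccnc3cc(Cl)ccc23)c(C#N)c(-c2ccccc2)n1`: 4000 nM
compound 2 `CSc1nc(NCCCCNc2ccnc3cc(Cl)ccc23)c(C#N)c(-c2ccc([N+](=O)[O-])cc2)n1`: 4000 nM
compound 3 `COc1ccc(-c2nc(SC)nc(NCCCCNc3ccnc4cc(Cl)ccc34)c2C#N)cc1`: 20000 nM

Compound 3 gives the highest number of the three in this assay; compound 1 and compound 2 both sit lower, each by the same distance, and that distance is beyond the scatter. Among the compounds with values here, the only single-point step among the measured compounds is a 5.0-fold higher number from compound 2 to compound 3 (0.70 log units; beyond the scatter), methoxy in place of nitro on an aromatic carbon, which moved the number upward by a modest amount.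

Compound 4 `CSc1nc(NCCCCNc2ccnc3cc(Cl)ccc23)c(C#N)c(-c2ccc(C)cc2)n1` differs from compound 3 by methyl in place of methoxy on an aromatic carbon. Within the data shown here, no measured pair covers a methoxy-to-methyl exchange, so the one step on record bears on it only loosely: it shows that the group at this position of the aryl ring can shift the tolerated concentration by a modest margin, but gives no direction for a methyl. With nothing pointing either way, the expectation is for compound 4 to stay close to compound 3, with a step of a 1.3-fold lower number from compound 3 to compound 4 (0.12 log units; within the scatter) that is estimated to remain within the scatter.

Compound 4 is therefore estimated at 15000 nM in this assay, with a range from 6000 nM to 30000 nM.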

Compound 4, minimum cytotoxic concentration: 20000 nM
Beside the measured number, compound 4's estimate is 1.3-fold (0.12 log units) below it, and the stated range covers the measured number.
By their numbers in this assay, from the lowest: compounds 1 and 2 (each within the scatter of the next); then compounds 3 and 4 (each within the scatter of the next).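

In this assay, the exchange of 4-methoxyphenyl for 4-methylphenyl gives no change at the digits printed from compound 3 to compound 4 (within the scatter), so this position tolerates the loss of the oxygen and its hydrogen-bond acceptor without any visible effect on the read-out. The second new step, a 5.0-fold higher number from compound 2 to compound 4 (0.70 log units; beyond the scatter), has the same size as a 5.0-fold higher number from compound 2 to compound 3 (0.70 log units; beyond the scatter), so two different replacements of nitro on this aromatic carbon arrive at the same number, and among compound 2, compound 3 and compound 4 only the nitro compound stands apart. Nothing at hand accounts for that separation or says what the methoxy and methyl groups have in common in this assay.

Going by these compounds, it remains open whether the nitro compound is a lone exception on this ring or one end of a wider spread, which an amine, a carboxylic acid or a chlorine at the same place would help to settle. Also open, on these data alone, is whether the equivalence of methoxy and methyl holds with a longer chain or with the ether link of compound 1 in place of the present one.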